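The source may hold more compounds than are shown below. What is called first, only, known or untested is meant among the compounds shown, and "the series" means these compounds.

Compound 1 `COc1cccc(CNCCCNc2ccnc3cc(-c4ccc(F)cc4)ccc23)c1O` and compound 2 `COc1ccc(F)cc1CNCCCNc1ccnc2cc(-c3ccc(F)cc3)ccc12` share one core. In an ADME assay for permeability, using PAMPA, with a stated time of 30 min, at pH 7.4 (a higher number here means that the compound crosses the layer faster, a lower number that the compound crosses the layer more slowly), compound 1 gives 237 10^-6 cm/s and compound 2 gives 237 10^-6 cm/s, so the step of no change at the digits printed from compound 1 to compound 2 (within the scatter) is flat. Compound 3 `COc1ccc(F)cc1CNCCCNc1ccnc2cc(CCc3ccccc3)ccc12` differs from compound 2 in phenethyl in place of 4-fluorophenyl on an aromatic carbon. Within the data shown here, no measured step touches this position, and the only known step, no change at the digits printed from compound 1 to compound 2 (within the scatter), concerns a different part of the molecule, so it offers no direction. Compound 3 is therefore expected to sit near compound 2, with a step of a 1.2-fold lower number from compound 2 to compound 3 (0.07 log units; within the scatter) within the scatter, estimated at 200 10^-6 cm/s in a range of 110 10^-6 cm/s to 320 10^-6 cm/s.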

Compound 3, apparent permeability: 23 10^-6 cm/s
The estimate for compound 3 lay 8.7-fold (0.94 log units) above the measured number; the measured number lies below the stated range.
By their numbers in this assay, from the lowest: compound 3; then compounds 1 and 2 (each within the scatter of the next).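

In this assay this aromatic carbon proves a sensitive position: phenethyl in place of 4-fluorophenyl gives a 10-fold lower number from compound 2 to compound 3 (1.01 log units; beyond the scatter) where the earlier change elsewhere in the molecule gave no change at the digits printed from compound 1 to compound 2 (within the scatter) and stayed flat. Among these compounds, then, the read-out responds to the group at this position and not to the one changed on the saturated chain carbon. No measurement shown here accounts for the fall.

The step changes the chain and removes the fluorine together, so the compounds shown cannot separate the two. An unsubstituted phenyl or a benzyl group at this position would begin to do so.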